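This account rests on a few compounds, and the source may have more. Where it says the series, first, only, none or still open, it means among the compounds named here.

Working notes on the series. Compound 3 `CCc1ccc(-c2cn3ccnc3c(-c3ccc4ncn(Cc5ccccc5)c4c3)n2)cc1` gives the highest of the three numbers in a functional assay on TK-10 cells (Homo sapiens) for inhibition, read by sulforhodamine B assay, with a stated time of 48 h, tested at 10 uM (a lower number here means less inhibition, a higher number more inhibition at the concentration tested (going by the name of the read-out)), at 15.5%. The next nearest is compound 2 `c1cn2cc(-c3ccsc3)nc(-c3ccc4ncn(C5CCCCC5)c4c3)c2n1`, which in this assay gives 3.37%, a number beyond the scatter below compound 3. The furthest is compound 1 `O=Cc1ccc(-c2cn3ccnc3c(-c3ccc4ncn(C5CCCCC5)c4c3)n2)cc1`, which in this assay gives 0.75%. Going by the values given here, the one measured step, a number 2.6 percentage points higher from compound 1 to compound 2 (within the scatter), lies within the scatter and concerns a different position from the one changed here.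

Compound 4 `O=Cc1ccc(-c2cn3ccnc3c(-c3ccc4ncn(Cc5ccccc5)c4c3)n2)cc1` differs from compound 3 in one place: formyl in place of ethyl on an aromatic carbon. Among the compounds with values here, no measured pair shows this change on the same core, so no step bears directly on it. Within the data shown here, the only compound that carries the 4-formylphenyl group, compound 1, gives the lowest number in this assay, but its core differs from that of compound 4, so this is a weak pointer only. A fall beyond the scatter is therefore expected, a number 10.5 percentage points lower from compound 3 to compound 4 (beyond the scatter), though with wide uncertainty. Compound 4 is estimated at 5%, with a range from 0% to 16%.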

Compound 4, a percentage reported as inhibition, at one concentration (the size of the read-out at that concentration, not a potency): 0.75%
Estimate against measurement, compound 4: 4.3 percentage points above; the range from low to high includes it.
By their numbers in this assay, from the lowest: compounds 1, 4 and 2 (each within the scatter of the next); then compound 3.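

In this assay, the change from 4-ethylphenyl to 4-formylphenyl now has a measured step on one core, a number 14.8 percentage points lower from compound 3 to compound 4 (beyond the scatter), so the group at this place does move the number on the core of compound 3. With 4-formylphenyl held constant, exchanging cyclohexyl for benzyl on the aromatic nitrogen shows nothing at this read-out, no change at the digits printed from compound 1 to compound 4 (within the scatter). Nothing available here bears on the reason for the fall with formyl.

The compounds shown leave open how an amine, a carboxylic acid or a chain longer than ethyl would read at this place on the six-membered aromatic ring. Also open, going by these compounds, is whether cyclohexyl on the aromatic nitrogen would match benzyl with 4-ethylphenyl in place, as it does with 4-formylphenyl.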